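The source may report more compounds than this note shows. Statements on the series, on what has been measured and on what is new or still open speak of the compounds shown alone.

Working notes on the series in a functional assay on MDA-MB-231 cells (Homo sapiens) for inhibition, read by MTT assay, with a stated time of 72 h; on this read-out lower numbers stand for stronger inhibition and higher numbers for weaker inhibition. Compound 1 `O=C(CSc1nc(Nc2ccccc2)c2ccccc2n1)Nc1ccc(F)c(Cl)c1` gives 21600 nM in this assay. Compound 2 `C=CC(=O)Nc1cccc(NC(=O)CSc2nc(Nc3ccccc3F)c3ccccc3n2)c1` gives 18700 nM in this assay. Among the compounds with values here, compound 2 thus has the lowest of the two numbers measured so far, but its value and that of compound 1 lie within the scatter of each other, and the two structures differ in more than one place, so the pair offers no single step to read.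

Compound 3 `C=CC(=O)Nc1cccc(NC(=O)CSc2nc(Nc3ccc(Cl)cc3)c3ccccc3n2)c1` is the next member and differs from compound 2 in one place: 4-chlorophenyl in place of 2-fluorophenyl on a nitrogen on an aromatic ring. Within the data shown here, no measured step of this kind exists yet, and the two measured compounds, which differ at this ring among other places, give numbers within the scatter of each other. For compound 3 the step expected from compound 2 is a 1.2-fold lower number from compound 2 to compound 3 (0.07 log units; within the scatter), small and not beyond the scatter in either direction. Compound 3 is estimated to give 16000 nM in this assay, with an expected range from 6000 nM to 45000 nM.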

Compound 3, half-maximal inhibitory concentration: 10300 nM
The estimate for compound 3 lay 1.6-fold (0.19 log units) above the measured number, and the stated range covers the measured number.
By their numbers in this assay, from the lowest: compounds 3, 2 and 1 (each within the scatter of the next, the first and the last beyond it).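

In this assay, within the data shown here, the exchange of 2-fluorophenyl for 4-chlorophenyl on the nitrogen gives a 1.8-fold lower number from compound 2 to compound 3 (0.26 log units; within the scatter) and is the first single-place step that can be read. At this position, then, a change in both the halogen and its place on the ring, with the heavy-atom count unchanged, does not produce a step beyond the scatter. No measurement of any property of these groups is available to account for the reading, and the step alone cannot separate the halogen from its place on the ring.

Still open, on these data alone, is how each of these two features counts alone, which 4-fluorophenyl or 2-chlorophenyl on the same nitrogen would address. Also open, as far as these compounds go, is whether a group of a different kind at this position, such as a 4-carboxyphenyl, a 4-(dimethylamino)phenyl or a saturated cyclohexyl ring, would give a step beyond the scatter.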